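The source may report more compounds than this note shows. Statements on the series, on what has been measured and on what is new or still open speak of the compounds shown alone.

In a functional assay on the whole organism (blood) with Rattus norvegicus as the target, with stated times of 24 h and 1 h, at a dose of 5 mg/kg by the intraperitoneal route (on this read-out lower numbers stand for a weaker effect and higher numbers for a stronger effect at the one dose given), compound 1 `O=C(NC1CCCCC1)NS(=O)(=O)N1CCC(CCNC(=O)C(F)(F)F)CC1` gives 13%. Compound 2 `O=C(NC[C@@H]1C[C@@H]2C=C[C@@H]1C2)NS(=O)(=O)N1CCC(CCNC(=O)C(F)(F)F)CC1` differs from it by a group of 8 heavy atoms (8 carbon; 2 five-membered non-aromatic rings of carbon only) in place of a group of 6 heavy atoms (6 carbon; one six-membered non-aromatic ring of carbon only), on an amide-type nitrogen; in this assay compound 2 gives 22%, a step of a number 9 percentage points higher from compound 1 to compound 2 (within the scatter). Compound 3 `O=C(NC1CCCCC1)NS(=O)(=O)N1CCC(CCNC(=O)c2ccc3ccccc3n2)CC1` carries a different core, the two cores differing by quinolin-2-yl in place of trifluoromethyl on a carbonyl carbon; in this assay compound 3 gives 11%, a step of a number 2 percentage points lower from compound 1 to compound 3 (within the scatter). Compound 4 `O=C(NC[C@@H]1C[C@@H]2C=C[C@@H]1C2)NS(=O)(=O)N1CCC(CCNC(=O)c2ccc3ccccc3n2)CC1` has not yet been tested. It differs from compound 3 by a group of 8 heavy atoms (8 carbon; 2 five-membered non-aromatic rings of carbon only) in place of a group of 6 heavy atoms (6 carbon; one six-membered non-aromatic ring of carbon only), on an amide-type nitrogen, the same change that turns compound 1 into compound 2, now made on the core of compound 3. For the measured compounds named here, the expected size of the step is a number 9 percentage points higher from compound 3 to compound 4 (within the scatter), matching the earlier step because a number 9 percentage points higher from compound 1 to compound 2 (within the scatter) is the only precedent for this change. Going by the values given here, with the second core only one measured compound exists, so this rests on a single example. Compound 4 is therefore expected to give about 20%, likely between 8% and 32%.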

Compound 4, a percentage reported as activity, at one dose (the size of the read-out at that dose, not a potency): 21%
Estimate against measurement, compound 4: 1 percentage points below; the measured number falls inside the stated range.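

In this assay, putting the group of 8 carbon atoms in place of cyclohexyl gives a number 10 percentage points higher from compound 3 to compound 4 (within the scatter), and this agrees with the earlier step on the other core: the same change on two cores in this assay, a number 9 percentage points higher (within the scatter) from compound 1 to compound 2 and a number 10 percentage points higher (within the scatter) from compound 3 to compound 4, 1 percentage points apart, within the scatter of two such steps. Putting quinolin-2-yl in place of trifluoromethyl gives a number 1 percentage points lower from compound 2 to compound 4 (within the scatter), and this change also carries over: the same change on two cores in this assay, a number 2 percentage points lower (within the scatter) from compound 1 to compound 3 and a number 1 percentage points lower (within the scatter) from compound 2 to compound 4, 1 percentage points apart, within the scatter of two such steps. Each change therefore behaves alike on the two cores, but every step lies within the scatter, so neither change is shown to have a real effect, and two cores cannot show that this agreement would extend to other cores.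

Still open, from the compounds shown here alone, is how either change would behave with phenyl on the carbonyl carbon. The same question applies to a core with a free amine in place of the amide.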